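This account rests on a few compounds, and the source may have more. Where it says the series, first, only, none or still open, it means among the compounds named here.

In an ADME assay (liver) for metabolic stability, with Liver microsome (Rattus norvegicus) as the target, using microsomes and NADPH, with a stated time of 30 min, tested at 1 uM (on this read-out higher numbers stand for fast clearance and lower numbers for slow clearance), compound 1 `NC(=O)c1cccc(-c2cc(C(O)(C(F)(F)F)C(F)(F)F)cnc2N2CCN(S(=O)(=O)c3ccc(N)nc3)CC2)c1` gives 63 mL.min-1.g-1, compound 2 `CS(=O)(=O)c1ccc(-c2cc(C(O)(C(F)(F)F)C(F)(F)F)cnc2N2CCN(S(=O)(=O)c3ccc(N)nc3)CC2)cc1` gives 103 mL.min-1.g-1 and compound 3 `Nc1ccc(S(=O)(=O)N2CCN(c3ncc(C(O)(C(F)(F)F)C(F)(F)F)cc3-c3cncc(F)c3)CC2)cn1` gives 19 mL.min-1.g-1, the lowest of the three. Compound 4 `COc1cncc(-c2cc(C(O)(C(F)(F)F)C(F)(F)F)cnc2N2CCN(S(=O)(=O)c3ccc(N)nc3)CC2)c1` differs from compound 3 at one place, with methoxy in place of fluoro on an aromatic carbon. Going by the values given here, no measured step makes this exact change. The closest evidence is replacement of the whole aromatic group, seen in a 3.3-fold lower number from compound 1 to compound 3 (0.52 log units; beyond the scatter) and a 5.4-fold lower number from compound 2 to compound 3 (0.73 log units; beyond the scatter), both modest, while a 1.6-fold higher number from compound 1 to compound 2 (0.21 log units; within the scatter) stays within the scatter. Since compound 3 holds the lowest value, some drift towards compound 1 at 63 mL.min-1.g-1 is expected. The expected step is small and upward: a 1.8-fold higher number from compound 3 to compound 4 (0.27 log units; within the scatter). Compound 4 is estimated at 35 mL.min-1.g-1, within an expected range of 14 mL.min-1.g-1 to 80 mL.min-1.g-1.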

Compound 4, intrinsic clearance in microsomes: 58 mL.min-1.g-1
Beside the measured number, compound 4's estimate is 1.7-fold (0.22 log units) below it; low and high end bracket the measured number.
By their numbers in this assay, from the lowest: compound 3; then compounds 4, 1 and 2 (each within the scatter of the next).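

In this assay, exchanging only the ring substituent, methoxy in place of fluoro, gives a 3.1-fold higher number from compound 3 to compound 4 (0.48 log units; beyond the scatter) and so shows that the low number of compound 3 does not come with the pyridine ring alone. Compound 4 instead sits with the phenyl compounds, with a 1.1-fold lower number from compound 1 to compound 4 (0.04 log units; within the scatter) and a 1.8-fold lower number from compound 2 to compound 4 (0.25 log units; within the scatter) both within the scatter. No measurement shown here accounts for the step. Still open, from the compounds shown here alone, is whether a chloro, a nitrile or an amine on this carbon would give a number close to that of compound 3 or to that of compound 4.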